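Series notes: acetylpiperidinyl ether analogue of compound 2

The source may hold more compounds than are shown below. What is called first, only, known or untested is meant among the compounds shown, and "the series" means these compounds.

The shared core carries a para-substituted phenyl ether in compound 1 `CN1CCC(Oc2ccc(-c3nc4cc(C(N)=O)ccc4[nH]3)cc2)C1`, compound 2 `NC(=O)c1ccc2[nH]c(-c3ccc(OCCCN4CCCCC4)cc3)nc2c1` and compound 3 `COc1ccc(CN2CCCCC2CCOc2ccc(-c3nc4cc(C(N)=O)ccc4[nH]3)cc2)cc1`. In a physicochemical assay for solubility, with a stated time of 3 days, at pH 7 (a higher number here means a more soluble compound, a lower number a less soluble compound), compound 1 gives "not determined" (no result reported). In this assay compound 2 reaches only a limit, > 400000 nM, which is not a number. Compound 3 gives 84000 nM in this assay. Compound 2 therefore stands at the limit of > 400000 nM in this assay, at which 1 of the 3 values shown sits, with the remaining entries giving no single figure beside it. Compound 4 `CC(=O)N1CCC(CCOc2ccc(-c3nc4cc(C(N)=O)ccc4[nH]3)cc2)CC1` differs from compound 2 by 1-acetylpiperidin-4-yl in place of (piperidin-1-yl)methyl on a saturated chain carbon, two bonds along the chain from an oxygen on an aromatic ring. Going by the values given here, no measured step covers this change. Compound 4 is expected to sit below compound 2, with a step of an at least 8.0-fold lower number from compound 2 to compound 4 (0.90 log units; beyond the scatter) in this assay, and its solubility is estimated at 50000 nM, between 10000 nM and 200000 nM.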

Compound 4, solubility: 2000 nM
Compound 4: the middle estimate sits 25-fold (1.40 log units) above what was measured, outside the stated range (below it).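

In this assay, 1-acetylpiperidin-4-yl in place of (piperidin-1-yl)methyl on a saturated chain carbon, two bonds along the chain from an oxygen on an aromatic ring, gives an at least 200-fold lower number from compound 2 to compound 4 (2.30 log units; beyond the scatter). Going by these compounds alone, this is the first measured step at this position, and it shows that the read-out responds strongly to this change. The entry for compound 2 is a limit, not a number: the limit of > 400000 nM in this assay, at which 1 of the 4 values shown sits.

The step does not separate the acetyl group from the change in how the piperidine ring is attached to the chain. An unsubstituted piperidin-4-yl group, with its free amine, on the same chain would separate the two.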